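Arylidene thiosemicarbazones of a monoterpenoid amine: cytotoxicity notes

The source may hold more compounds than are shown below. What is called first, only, known or untested is meant among the compounds shown, and "the series" means these compounds.

Measured in a functional assay on K562 cells (Homo sapiens) for cytotoxicity, read by sulforhodamine B assay; on this read-out lower numbers stand for stronger inhibition of growth and higher numbers for weaker inhibition of growth:
compound 1 `CC1=CC[C@@H]([C@@](C)(O)CCCC(C)(C)NC(=S)NN)CC1`: 20 nM
compound 2 `CC1=CC[C@@H]([C@@](C)(O)CCCC(C)(C)NC(=S)N/N=C\c2cccc(Cl)c2)CC1`: 30 nM
compound 3 `CC1=CC[C@@H]([C@@](C)(O)CCCC(C)(C)NC(=S)N/N=C\c2ccc(Cl)cc2)CC1`: 40 nM

Compound 3 sits within the usual scatter of both other compounds: a 1.3-fold higher number from compound 2 to compound 3 (0.12 log units; within the scatter), and a 2.0-fold higher number from compound 1 to compound 3 (0.30 log units; within the scatter). The free hydrazide, compound 1, and the two chlorophenyl hydrazones are therefore not separated by the numbers shown.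

Compound 4 `CC1=CC[C@@H]([C@@](C)(O)CCCC(C)(C)NC(=S)N/N=C(/C)c2ccccc2)CC1` differs from compound 3 in that (a group of 9 heavy atoms (8 carbon, 1 nitrogen; one six-membered aromatic ring of carbon only) in place of a group of 9 heavy atoms (7 carbon, 1 nitrogen, 1 chlorine; one six-membered aromatic ring of carbon only), on an amide-type nitrogen). Two kinds of step bear on this change. The aryl swap a 1.3-fold higher number from compound 2 to compound 3 (0.12 log units; within the scatter) was within the scatter, as were the additions of an arylidene unit to the hydrazide, a 1.5-fold higher number from compound 1 to compound 2 (0.18 log units; within the scatter) and a 2.0-fold higher number from compound 1 to compound 3 (0.30 log units; within the scatter). Among the measured compounds shown here, nothing among the measured compounds speaks for a substantial move in either direction when the chlorine is removed and a methyl enters on the carbon with a double bond to nitrogen, so the expectation for compound 4 in this assay is a number close to that of compound 3.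

Compound 4 is expected to give 40 nM, in the range 15 nM to 110 nM, which means an estimated step of no change at the digits printed from compound 3 to compound 4 (within the scatter).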

Compound 4, concentration for 50% growth inhibition: 10 nM
Compound 4: middle estimate off by 4.0-fold (0.60 log units), on the high side; the measured number lies below the stated range.
By their numbers in this assay, from the lowest: compounds 4, 1, 2 and 3 (each within the scatter of the next, the first and the last beyond it).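

On the amide-type nitrogen, the arylidene group can separate compounds in this assay, which the swap between the two chlorophenyl groups did not do: the new group gives steps beyond the scatter against both chlorophenyl hydrazones (a 4.0-fold lower number from compound 3 to compound 4 (0.60 log units; beyond the scatter); a 3.0-fold lower number from compound 2 to compound 4 (0.48 log units; beyond the scatter)). Against the free hydrazide the new group stays unresolved (a 2.0-fold lower number from compound 1 to compound 4 (0.30 log units; within the scatter)), so the arylidene unit is not shown to improve on the unsubstituted hydrazide. No measurement available for this series gives a reason for the separation.

The change removes the chlorine and places a methyl on the carbon with a double bond to nitrogen in a single step, so the compounds shown do not assign the step to either alteration. Also open, going by these compounds, is how a pyridine ring in place of the phenyl, or an ethyl in place of the methyl, would read in this assay.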